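Aryloxy swap on the shared core: cytotoxicity outlook

The source may report more compounds than this note shows. Statements on the series, on what has been measured and on what is new or still open speak of the compounds shown alone.

Measured compounds:
compound 1 `COc1ccccc1Oc1ccc2c(NCCCNCc3ccco3)ccnc2c1`: 6500 nM
compound 2 `COc1ccc(Oc2ccc3c(NCCCNCc4cc(F)ccc4OC)ccnc3c2)cc1`: 7000 nM
compound 3 `COc1ccc(F)cc1CNCCCNc1ccnc2cc(C3CCCCC3)ccc12`: 2290 nM

In an ADME assay on HepG2 cells (Homo sapiens) for cytotoxicity, read by luminescence, CellTiter-Glo and ATP content, with a stated time of 72 h (a lower number here means that less compound is needed, a higher number that more compound is needed for the effect), compound 1 gives 6500 nM. Among the three numbers in this assay it stands second highest; compound 2 gives 7000 nM, which lies within the scatter of compound 1, so no order between the two can be read. Compound 3 gives 2290 nM, a lower number than compound 1 that lies beyond the scatter.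

Compound 4 `Fc1ccc(Oc2ccc3c(NCCCNCc4ccco4)ccnc3c2)cc1` is the unmeasured compound. It differs from compound 1 in one place: 4-fluorophenyl in place of 2-methoxyphenyl on an oxygen on an aromatic ring.

Among the compounds with values here, only one step between measured compounds is available, a 3.1-fold lower number from compound 2 to compound 3 (0.49 log units; beyond the scatter), and it concerns a different change, the replacement of a whole aryloxy group by cyclohexyl. Within the data shown here, no measured step bears directly on an exchange of one aryl group for another on the oxygen. Compounds 1 and 2, which carry different aryl groups on the oxygen alongside other differences, give numbers within the scatter of each other. On that basis no step beyond the scatter is expected in this assay from compound 1 to compound 4, and the expected step is no change at the digits printed from compound 1 to compound 4 (within the scatter).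

Compound 4 is therefore estimated at 6500 nM in this assay, with a range from 3000 nM to 14000 nM.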

Compound 4, half-maximal effective concentration: 16000 nM
Estimate against measurement, compound 4: 2.5-fold (0.39 log units) below; measured number above the stated range.
By their numbers in this assay, from the lowest: compound 3; then compounds 1 and 2 (each within the scatter of the next); then compound 4.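

In this assay, the exchange of 2-methoxyphenyl for 4-fluorophenyl on an oxygen on an aromatic ring gives a 2.5-fold higher number from compound 1 to compound 4 (0.39 log units; beyond the scatter), which shows that the number responds to the aryl group alone, with the oxygen and the rest of compound 1 left in place. Within the data shown here, the only earlier step at this place, a 3.1-fold lower number from compound 2 to compound 3 (0.49 log units; beyond the scatter), removed the whole 4-methoxyphenoxy group in favour of cyclohexyl, so it could not show what an exchange on the oxygen does; the two steps also start from different compounds and run in opposite directions, and they establish no trend together. No measurement among the data given accounts for the size or the direction of the new step.

The compounds shown leave open which part of the exchange carries the step, the 2-methoxyphenyl leaving or the 4-fluorophenyl entering, and a plain phenyl or a pyridine ring on the same oxygen would help to separate the two. Also open, from the compounds shown here alone, is whether the same exchange gives a similar step when the rest of the molecule is that of compound 2.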